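Metabolic stability notes: amine variation on the chain carbon

The source may hold more compounds than are shown below. What is called first, only, known or untested is meant among the compounds shown, and "the series" means these compounds.

The series shares one core; compound 3 is `COc1ccc2[nH]c(C(=O)N3CC(=O)N(Cc4ccccc4)[C@@H](CN4CC5CCCCC5C4)C3)cc2c1` and in an ADME assay on microsomes from liver (Homo sapiens) for metabolic stability, with a stated time of 30 min, tested at 1 uM (on this read-out higher numbers stand for a longer-lived compound and lower numbers for a shorter-lived compound), compound 3 gives 0.233 h. Compound 2 is `COc1ccc2[nH]c(C(=O)N3CC(=O)N(Cc4ccccc4)[C@@H](CN4CCCCC4)C3)cc2c1` and in this assay compound 2 gives 0.283 h; compound 1 is `COc1ccc2[nH]c(C(=O)N3CC(=O)N(Cc4ccccc4)[C@@H](CCc4ccccc4)C3)cc2c1` and in this assay compound 1 gives 0.167 h. Both neighbours sit within scatter of compound 3: a 1.2-fold lower number from compound 2 to compound 3 (0.08 log units; within the scatter) and a 1.4-fold higher number from compound 1 to compound 3 (0.14 log units; within the scatter), and also a 1.7-fold higher number from compound 1 to compound 2 (0.23 log units; within the scatter). Compound 4 is `COc1ccc2[nH]c(C(=O)N3CC(=O)N(Cc4ccccc4)[C@@H](CN4CCCc5ccccc54)C3)cc2c1`, differing from compound 3 by a group of 10 heavy atoms (9 carbon, 1 nitrogen; one six-membered non-aromatic ring with 1 hetero atom, one six-membered aromatic ring of carbon only) in place of a group of 9 heavy atoms (8 carbon, 1 nitrogen; one five-membered non-aromatic ring with 1 hetero atom, one six-membered non-aromatic ring of carbon only), on a saturated chain carbon bound to a saturated ring carbon. Three changes at this same place have all stayed within scatter, so for compound 4 the expected step is a 1.0-fold higher number from compound 3 to compound 4 (0.01 log units; within the scatter). Compound 4 is therefore estimated at 0.24 h, with a range from 0.12 h to 0.48 h.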

Compound 4, half-life: 0.183 h
For compound 4 the middle estimate is 1.3-fold (0.12 log units) above the measured one, within the range that was stated.
By their numbers in this assay, from the lowest: compounds 1, 4, 3 and 2 (each within the scatter of the next).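

Placing 1,2,3,4-tetrahydroquinolin-1-yl on the saturated chain carbon gives a 1.3-fold lower number from compound 3 to compound 4 (0.10 log units; within the scatter) and a 1.5-fold lower number from compound 2 to compound 4 (0.19 log units; within the scatter) and a 1.1-fold higher number from compound 1 to compound 4 (0.04 log units; within the scatter) in this series. Benzyl, piperidin-1-yl, the group of compound 3 and 1,2,3,4-tetrahydroquinolin-1-yl therefore remain inseparable at this place in this assay, now including an amine with a six-membered aromatic ring of carbon only. No supporting measurement bears on this result.

As far as these compounds go, whether a carboxylic acid, morpholin-4-yl or an open-chain dialkylamine at this place would move the half-life beyond the scatter stays open. So does whether a change elsewhere on the shared core would.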